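This account rests on a few compounds, and the source may have more. Where it says the series, first, only, none or still open, it means among the compounds named here.

Compound 3, `O=C(NCc1cc(Cl)ccc1-n1cnnn1)[C@@H]1CC=NN1C(=O)[C@H](O)c1ccccc1F`, stands second highest of the three numbers in an ADME assay on Caco-2 cells (Homo sapiens) for permeability, read by LC-MS, in the apical to basolateral direction, with a stated time of 60 min, at pH 6.5 (a lower number here means that the compound crosses the layer more slowly, a higher number that the compound crosses the layer faster), where compound 3 gives 8.9 10^-6 cm/s. Its nearest neighbour is compound 2, `Cc1cccc([C@@H](O)C(=O)N2N=CC[C@H]2C(=O)NCc2cc(Cl)ccc2-n2cnnn2)c1`, which in this assay gives 9.7 10^-6 cm/s; the step of a 1.1-fold lower number from compound 2 to compound 3 (0.04 log units; within the scatter) lies within the scatter. Its furthest neighbour is compound 1, `COC(C)(C)[C@@H](O)C(=O)N1N=CC[C@H]1C(=O)NCc1cc(Cl)ccc1-n1cnnn1`, which gives 1.7 10^-6 cm/s, and the step of a 5.2-fold higher number from compound 1 to compound 3 (0.72 log units; beyond the scatter) is beyond the scatter, as is a 5.7-fold higher number from compound 1 to compound 2 (0.76 log units; beyond the scatter).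

Compound 4 is `O=C(NCc1cc(Cl)ccc1-n1cnnn1)[C@@H]1CC=NN1C(=O)[C@H](O)C1CCCCC1`. It differs from compound 3 in one place: cyclohexyl in place of 2-fluorophenyl on a saturated chain carbon bound to a carbonyl carbon and an oxygen on a saturated carbon. Of the measured steps, only those at the same place bear on this one. Going by the values given here, the two steps that put an aromatic ring where 1-methoxy-1-methylethyl had been each brought a modest rise, while the one step that exchanges one ring for another at that place, from compound 2 to compound 3, stayed within the scatter. Among the compounds with values here, no measured step puts a cyclohexyl in at this position, so the expectation rests on the ring-for-ring exchange alone. For compound 4 the step of a 1.0-fold higher number from compound 3 to compound 4 (0.00 log units; within the scatter) is expected to stay within the scatter. Compound 4 is therefore estimated at 9 10^-6 cm/s, with a range from 4.5 10^-6 cm/s to 18 10^-6 cm/s.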

Compound 4, apparent permeability: 19 10^-6 cm/s
Compound 4: the middle estimate sits 2.1-fold (0.32 log units) below what was measured; the whole stated range lies below it.
By their numbers in this assay, from the lowest: compound 1; then compounds 3, 2 and 4 (each within the scatter of the next, the first and the last beyond it).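

Going by these compounds alone, at this position the higher numbers do not depend on an aromatic ring: in this assay the step of a 2.1-fold higher number from compound 3 to compound 4 (0.33 log units; beyond the scatter) is the first ring-for-ring exchange to pass the scatter, while the step of a 2.0-fold higher number from compound 2 to compound 4 (0.29 log units; within the scatter) stays within it, so the two aromatic compounds do not give one answer on whether cyclohexyl stands apart from the aromatic rings. The step of an 11-fold higher number from compound 1 to compound 4 (1.05 log units; beyond the scatter) is the only large one at this place, and it shows the gap between 1-methoxy-1-methylethyl and a ring to be wider than compounds 2 and 3 had shown. Nothing at hand accounts for these differences.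

The compounds shown leave open whether a smaller carbon ring such as cyclopentyl, or a ring carrying a nitrogen such as piperidinyl, would stay level with compound 4. Within the data shown here, with 1-methoxy-1-methylethyl as the only group here without a ring, they also cannot separate the absence of a ring from the presence of the methoxy group, a question that a plain branched chain such as tert-butyl would address.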